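This account rests on a few compounds, and the source may have more. Where it says the series, first, only, none or still open, it means among the compounds named here.

Compound 3 `CCOC(=O)C(O)Cn1cnc2c(N)ncnc21` carries an ethyl on an oxygen next to a carbonyl group of the shared core. In a functional assay on PRK cells (Oryctolagus cuniculus) for cytotoxicity (a lower number here means that less compound is tolerated, a higher number that more compound is tolerated), compound 3 gives > 400 ug/mL, which is a limit of the assay rather than a measured number. Compound 1 `CC(C)(C)OC(=O)C(O)Cn1cnc2c(N)ncnc21` likewise gives only a limit, > 400 ug/mL. Compound 2 `Nc1ncnc2c1ncn2CC(O)C(=O)OCCO` also gives only a limit, > 400 ug/mL. All three values sit at the limit of > 400 ug/mL in this assay, at which 3 of the 3 values shown sit, so the steps a step that the two limits leave unreadable from compound 1 to compound 2, a step that the two limits leave unreadable from compound 1 to compound 3 and a step that the two limits leave unreadable from compound 2 to compound 3 cannot be sized. Compound 4 `Nc1ncnc2c1ncn2CC(O)C(=O)OC1CCCCC1` differs from compound 3 by cyclohexyl in place of ethyl on an oxygen next to a carbonyl group. Nothing measured here shows tolerance moving with this part of the molecule, so compound 4 is expected to give an estimate of 400 ug/mL, between 200 ug/mL and 800 ug/mL. The step of a number no higher from compound 3 to compound 4 (the limit leaves the size open) is thus expected to stay within the scatter.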

Compound 4, minimum cytotoxic concentration: 100 ug/mL
Compound 4: the middle estimate sits 4.0-fold (0.60 log units) above what was measured, outside the stated range (below it).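

In this assay, the oxygen next to a carbonyl group now shows that this position can change how much compound is tolerated: cyclohexyl gives an at least 4.0-fold lower number from compound 3 to compound 4 (0.60 log units; beyond the scatter), along with an at least 4.0-fold lower number from compound 2 to compound 4 (0.60 log units; beyond the scatter) and an at least 4.0-fold lower number from compound 1 to compound 4 (0.60 log units; beyond the scatter). Of the groups shown on this oxygen, only cyclohexyl yields a measured number. The full size of each step stays open, since the other three compounds rest on a limit: the limit of > 400 ug/mL in this assay, at which 3 of the 4 values shown sit.

Going by these compounds, whether the ring itself or simply the larger number of carbons drives the change remains open. A straight hexyl chain on the same oxygen would separate the two.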